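This account rests on a few compounds, and the source may have more. Where it says the series, first, only, none or still open, it means among the compounds named here.

Measured so far:
compound 1, `COc1cc2nc(N3CCN(c4ccncn4)CC3)nc(N)c2cc1OC`, 0.27 nM;
compound 2, `CCCOc1ccnc(N2CCN(c3nc(N)c4cc(OC)c(OC)cc4n3)CC2)n1`, 0.32 nM;
compound 3, `COc1cc2nc(N3CCN(c4nccc(-c5ccccc5)n4)CC3)nc(N)c2cc1OC`, 1.66 nM.

In an assay on brain for binding affinity to Adrenergic receptor alpha-1 (Rattus norvegicus) (a higher number here means a weaker inhibitor, a lower number a stronger inhibitor), compound 2 stands second highest of the three numbers, close to compound 1 at 0.27 nM, while compound 3 gives 1.66 nM. Compound 4, `COc1nc(OC)nc(N2CCN(c3nc(N)c4cc(OC)c(OC)cc4n3)CC2)n1`, carries 4,6-dimethoxy-1,3,5-triazin-2-yl in place of 4-propoxypyrimidin-2-yl on an amine nitrogen in a ring. Among the compounds with values here, two measured steps bear on this change. The swap of one aromatic heterocycle for another, a 1.2-fold higher number from compound 1 to compound 2 (0.07 log units; within the scatter), left the number essentially unchanged, whereas replacing the propoxy chain by a phenyl, a 5.2-fold higher number from compound 2 to compound 3 (0.71 log units; beyond the scatter), weakened binding modestly. Since compound 4 keeps an alkoxy-bearing heterocycle on the same ring nitrogen, it is expected to sit near compound 2, with at most a small loss, a 1.4-fold higher number from compound 2 to compound 4 (0.15 log units; within the scatter). Compound 4 is therefore estimated at 0.45 nM, within 0.15 nM to 1.4 nM.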

Compound 4, inhibition constant: 0.08 nM
Compound 4: the middle estimate sits 5.6-fold (0.75 log units) above what was measured, and the stated range ends above it.
By their numbers in this assay, from the lowest: compound 4; then compounds 1 and 2 (each within the scatter of the next); then compound 3.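

In this assay, 4,6-dimethoxy-1,3,5-triazin-2-yl on the amine nitrogen in the ring gives stronger binding than 4-propoxypyrimidin-2-yl (a 4.0-fold lower number from compound 2 to compound 4 (0.60 log units; beyond the scatter)) and than pyrimidin-4-yl (a 3.4-fold lower number from compound 1 to compound 4 (0.53 log units; beyond the scatter)). The earlier exchange of heterocycles stayed within the scatter, so this position is now shown to allow a real gain as well as a loss. Nothing available here explains that gain. Going by these compounds, it remains open whether the gain would survive if an amine or an ethoxy group replaced either methoxy on the 1,3,5-triazin-2-yl ring.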